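This account rests on a few compounds, and the source may have more. Where it says the series, first, only, none or still open, it means among the compounds named here.

Of the compounds shown here, two have been measured in a functional assay on HepG2 cells (Homo sapiens) for inhibition, read by MTT assay, with a stated time of 72 h; a lower number here means a stronger inhibitor, a higher number a weaker inhibitor. Compound 1 (`COc1cc(/C=C/C(=O)c2c(O)cc(O)cc2OC)cc(OC)c1OC`) gives 20400 nM, and compound 2 (`COc1cc(OC)c(C(=O)/C=C/c2ccc([N+](=O)[O-])cc2)c(OC)c1`) gives 9400 nM. This is the lower of the two numbers, and the gap between them lies beyond the usual scatter, so compound 2 is the stronger inhibitor of this pair. Compound 3 (`COc1cc(OC)c(C(=O)/C=C/c2ccc(N)cc2)c(OC)c1`) differs from compound 2 in one place, on an aromatic carbon of a six-membered aromatic ring of carbon only, para to a large group, where amino stands in place of nitro: amino in place of nitro on an aromatic carbon. Among the compounds with values here, no measured pair shows this change, so the data give no direct guide to its size. In this assay only a small step toward a lower number is expected, one within the scatter: the estimated step is a 1.3-fold lower number from compound 2 to compound 3 (0.13 log units; within the scatter). The estimated value for compound 3 is 7000 nM, with an expected range of 2500 nM to 20000 nM.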

Compound 3, half-maximal inhibitory concentration: 45200 nM
Estimate against measurement, compound 3: 6.5-fold (0.81 log units) below, and the stated range ends below it.
By their numbers in this assay, from the lowest: compound 2; then compound 1; then compound 3.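

In this assay, within the data shown here, the place para to a large group on the six-membered aromatic ring turns out to matter: amino in place of nitro brings a 4.8-fold higher number from compound 2 to compound 3 (0.68 log units; beyond the scatter) and so gives the first direct reading of this change, one that lies beyond the scatter. In this single pair, nitro goes with the lower number and amino with the higher one, so the change weakens inhibition at this place. No evidence on the cause of this step is at hand.

The compounds shown leave open how other groups at this place would compare with nitro and amino, for example a methoxy group, an acetamide or a carboxylic acid. They also leave open whether amino in place of nitro would move the number the same way at another place on the ring.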